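This account rests on a few compounds, and the source may have more. Where it says the series, first, only, none or still open, it means among the compounds named here.

Measured so far:
Compound 1, `O=c1c(C2=CS(=O)(=O)c3cc(F)ccc3N2)c(O)c2cc(F)ccc2n1Cc1ccc(F)cc1` — an ADME assay on 2209-23 cells (Homo sapiens) for cytotoxicity, read by WST assay; a lower number here means that less compound is tolerated, a higher number that more compound is tolerated: > 50000 nM.
Compound 2, `Cc1cc(Cn2c(=O)c(C3=CS(=O)(=O)c4cc(NS(C)(=O)=O)ccc4N3)c(O)c3cc(F)ccc32)ccc1F` — this assay: > 50000 nM.

For compound 1, the value in this assay is a limit of the assay and not a number. For compound 2 as well, the value in this assay is a limit and not a number. Among the compounds with values here, both values sit at the limit of > 50000 nM in this assay, at which 2 of the 2 values shown sit, so compound 2 stands exactly where the one other measured compound stands, and with neither value a number no order between the two can be read.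

Compound 3, `CCCC(C)n1c(=O)c(C2=CS(=O)(=O)c3cc(NS(C)(=O)=O)ccc3N2)c(O)c2cc(F)ccc21`, is not yet measured. It differs from compound 2 in one place: 1-methylbutyl in place of 4-fluoro-3-methylbenzyl on an aromatic nitrogen. No step between measured compounds is shown, so the numbers give no direction to expect from this change. Because compound 1 and compound 2 both sit at the limit of > 50000 nM in this assay, at which 2 of the 2 values shown sit, compound 3 is expected to be reported only as a limit as well. The expected step of a number no higher from compound 2 to compound 3 (the limit leaves the size open) is therefore none beyond the scatter. Compound 3 is estimated to give about 50000 nM in this assay, within the range 25000 nM to 100000 nM.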

Compound 3, half-maximal cytotoxic concentration: > 50000 nM
Compound 3: only a limit was reported; the forecaster's own chance of this, stated with the estimate: 70%; the middle value sits exactly at the limit.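

In this assay compound 3 gives > 50000 nM as a limit of the assay and not a number. Within the data shown here, compound 2 also carries a limit, so no step from compound 2 to compound 3 can be read. All the compounds shown stand at the same place: the limit of > 50000 nM in this assay, at which 3 of the 3 values shown sit. They leave open what concentration reaches the half-maximal cytotoxic read-out, and whether 1-methylbutyl in place of 4-fluoro-3-methylbenzyl changes it.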